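Replacing fluoro with bromo on an aromatic carbon

A few compounds are considered here, and "the series" means these few. Any claim that something is new, unique, unknown or untested is made for them only; others in the source may bear on it.

In a functional assay on T47D cells (Homo sapiens) for antiproliferative activity, read by MTT assay, with a stated time of 72 h (on this read-out lower numbers stand for stronger inhibition and higher numbers for weaker inhibition), compound 1 `COc1cc(-c2nccn2-c2ccc(C)cc2)cc(OC)c1OC` gives 20500 nM. Compound 2 `COc1cc(-c2nccn2-c2ccc(F)cc2)cc(OC)c1OC` reaches only a limit of the assay, > 100000 nM. Compound 3 `COc1cc(-c2nccn2-c2ccc(Br)cc2)cc(OC)c1OC` has bromo in place of fluoro on an aromatic carbon, para to a large group. Going by the values given here, only one measured step bears on this change: putting fluoro in place of methyl gave an at least 4.8-fold higher number from compound 1 to compound 2 (0.68 log units; beyond the scatter), a change beyond the scatter. Replacing that fluoro with bromo is therefore expected to move the number back down, though by an uncertain amount. The expected change is an at least 3.3-fold lower number from compound 2 to compound 3 (0.52 log units; beyond the scatter). For compound 3, the estimated value is 30000 nM, within a range of 9000 nM to 90000 nM.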

Compound 3, half-maximal inhibitory concentration: 24600 nM
The estimate for compound 3 lay 1.2-fold (0.09 log units) above the measured number; the range from low to high includes it.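

In this assay, bromo in place of fluoro gives an at least 4.0-fold lower number from compound 2 to compound 3 (0.60 log units; beyond the scatter), so the loss seen with fluoro at this place is not shared by every halogen. On these data alone, the true size of that step stays unknown, as compound 2 gives only a limit and not a number: the limit of > 100000 nM in this assay, at which 1 of the 3 values shown sits. Bromo and methyl cannot be told apart here, with a 1.2-fold higher number from compound 1 to compound 3 (0.08 log units; within the scatter), a step within the scatter.

As far as these compounds go, whether chloro would behave like bromo or like fluoro remains open. So does whether an amine or a carboxylic acid at this place would keep the activity.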